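This account rests on a few compounds, and the source may have more. Where it says the series, first, only, none or still open, it means among the compounds named here.

Measured so far in a functional assay on A549 cells (Homo sapiens) for inhibition; a lower number here means a stronger inhibitor, a higher number a weaker inhibitor:
Compound 1 `COc1ccc(/C=C\c2ccc3ccccc3c2)cc1[N+](=O)[O-]`: > 20000 nM
Compound 2 `COc1cc(/C=C/c2ccc3ccccc3c2)cc([N+](=O)[O-])c1OC`: > 10000 nM

Both entries are limits, not numbers. Compound 2 stands at the limit of > 10000 nM, so its potency is not known as a number. Compound 1 likewise reaches only a limit, > 20000 nM. For the measured compounds named here, no step between measured compounds is available to guide a prediction.

Compound 3 `COc1cc(/C=C\c2ccc3ccccc3c2)cc([N+](=O)[O-])c1OC` is the next to be measured. The change is the two compounds have the same atoms and bonds and differ only in configuration as drawn: 1 of 1 stereo elements differ; a double bond is drawn E in compound 2 and Z in compound 3: a double bond is drawn E in compound 2 and Z in compound 3, with the same atoms and bonds.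

The expected step, an at least 1.2-fold lower number from compound 2 to compound 3 (0.09 log units; that floor lies within the scatter), is small and towards stronger inhibition, with a further limit about as likely as a number. This expectation starts from compound 2 at its limit of > 10000 nM, and no measured value points to a large change. Compound 3 is estimated at 8000 nM, with an expected range of 1500 nM to 30000 nM.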

Compound 3, half-maximal inhibitory concentration: 590 nM
Compound 3: middle estimate off by 14-fold (1.13 log units), on the high side; measured number below the stated range.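

In this assay, changing only the double bond from E to Z gives an at least 16-fold lower number from compound 2 to compound 3 (1.22 log units; beyond the scatter), and this step can be placed on the double bond alone because nothing else separates the pair: the fact that compounds 2 and 3 differ only in the configuration as drawn. The Z form does not carry the result by itself, since with the double bond drawn Z in both compounds, methoxy in place of hydrogen on an aromatic carbon gives an at least 33-fold lower number from compound 1 to compound 3 (1.53 log units; beyond the scatter). Both steps are floors rather than exact sizes, as each starts from a limit and not a number.

All the compounds shown carry the nitro group, so what an amine in its place would do remains open. Also open, on these data alone, is how a hydroxy group would read in place of the added methoxy.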